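This account rests on a few compounds, and the source may have more. Where it says the series, first, only, none or still open, it means among the compounds named here.

Measured compounds:
compound 1 `Cc1ccc(-c2c(C)nc(NS(=O)(=O)c3cccc4ccccc34)c(C)c2C(OC(C)(C)C)C(=O)O)cc1C` – in an ADME assay on MT4 cells (Homo sapiens) for cytotoxicity, read by MTT assay (on this read-out lower numbers stand for higher toxicity in this test and higher numbers for lower toxicity in this test), compound 1 gives 16000 nM
compound 2 `Cc1ccc(-c2c(C)nc(NC(=O)NC3CCCC3)c(C)c2C(OC(C)(C)C)C(=O)O)cc1C` – in this assay compound 2 gives 8000 nM
compound 3 `Cc1nc(NC(=O)NC2CCCCC2)c(C)c(C(OC(C)(C)C)C(=O)O)c1-c1ccc2c(c1)CCCO2` – in this assay compound 3 gives 17000 nM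

Compound 2 holds the lowest of the three numbers in this assay. Its gap to compound 1 is within the scatter, so the two cannot be told apart; its gap to compound 3 lies beyond it.

Compound 4 `Cc1ccc(-c2c(C)nc(NC(=O)NCc3ccccc3)c(C)c2C(OC(C)(C)C)C(=O)O)cc1C` differs from compound 2 at one place: benzyl in place of cyclopentyl on an amide-type nitrogen. Going by the values given here, no measured pair shows this change, so its direction is unknown. Starting from compound 2 with 8000 nM, the step of a 1.3-fold higher number from compound 2 to compound 4 (0.10 log units; within the scatter) is expected to stay within the scatter, in no set direction. Compound 4 is therefore estimated at 10000 nM, with a range from 4000 nM to 25000 nM.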

Compound 4, half-maximal cytotoxic concentration: 17000 nM
For compound 4 the middle estimate is 1.7-fold (0.23 log units) below the measured one; low and high end bracket the measured number.
By their numbers in this assay, from the lowest: compounds 2, 1, 3 and 4 (each within the scatter of the next, the first and the last beyond it).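

In this assay, benzyl in place of cyclopentyl on an amide-type nitrogen gives a 2.1-fold higher number from compound 2 to compound 4 (0.33 log units; beyond the scatter), a modest step towards lower toxicity in this test. This first one-place comparison shows that the group on this nitrogen can move the number beyond the scatter. Nothing at hand accounts for the step.

The compounds shown leave open whether a phenyl group or a straight hexyl chain on this nitrogen would move the number further. They also leave open whether a pyridylmethyl group would behave like benzyl.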